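Adding a methoxy group to compound 2: expected cytotoxicity

The source may hold more compounds than are shown below. What is called first, only, known or untested is meant among the compounds shown, and "the series" means these compounds.

Measured compounds, each with its value in an ADME assay on HEK293 cells (Homo sapiens) for cytotoxicity, read by MTT assay; a lower number here means a stronger inhibitor, a higher number a weaker inhibitor:
Compound 1 `COc1ccc(-n2ncn(Cc3cn(Cc4cc5ccccc5nc4Cl)nn3)c2=O)cc1` gives 958 ug/mL.
Compound 2 `Cc1cccc2cc(Cn3cc(Cn4cnn(-c5ccccc5)c4=O)nn3)c(Cl)nc12` gives 729 ug/mL.
Compound 3 `O=c1n(Cc2cn(Cc3cc4ccccc4nc3Cl)nn2)cnn1-c1ccccc1` gives 655 ug/mL.

Compound 2 sits second highest of the three numbers in this assay; its nearest neighbour is compound 3, with a 1.1-fold lower number from compound 2 to compound 3 (0.05 log units; within the scatter), and compound 1 lies furthest, though the two values above show that this gap also stays within the scatter. Compound 4 `COc1ccc(-n2ncn(Cc3cn(Cc4cc5cccc(C)c5nc4Cl)nn3)c2=O)cc1` differs from compound 2 by methoxy in place of hydrogen on an aromatic carbon. Among the measured compounds shown here, the one step that bears on this is the same change run backwards, a 1.5-fold lower number from compound 1 to compound 3 (0.17 log units; within the scatter), which stayed within the scatter. Accordingly, compound 4 is expected to show a 1.4-fold higher number from compound 2 to compound 4 (0.14 log units; within the scatter), a shift too small to count as real. The estimate for compound 4 in this assay is 1000 ug/mL, within a range from 500 ug/mL to 2000 ug/mL.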

Compound 4, half-maximal inhibitory concentration: 586 ug/mL
Beside the measured number, compound 4's estimate is 1.7-fold (0.23 log units) above it; measured number inside the range.
By their numbers in this assay, from the lowest: compounds 4, 3, 2 and 1 (each within the scatter of the next).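

In this assay, the change from phenyl to 4-methoxyphenyl has now been seen on a second core, where it gives a 1.2-fold lower number from compound 2 to compound 4 (0.09 log units; within the scatter). Adding methyl to an aromatic carbon of the core with the 4-methoxyphenyl group also stays small, with a 1.6-fold lower number from compound 1 to compound 4 (0.21 log units; within the scatter). Read in both directions, the methoxy change gives steps that agree within the scatter: the same change on two cores in this assay, a 1.5-fold lower number (0.17 log units; within the scatter) from compound 1 to compound 3 and a 1.2-fold higher number (0.09 log units; within the scatter) from compound 4 to compound 2, 1.8-fold (0.26 log units) apart, within the scatter of two such steps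

These compounds leave open whether another group in the same place, such as an amine or a carboxylic acid, would move the number beyond the scatter.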